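A few compounds are considered here, and "the series" means these few. Any claim that something is new, unique, unknown or untested is made for them only; others in the source may bear on it.

Measured so far:
compound 1, `CCCCCCOC(=O)CCC(=O)N1CCN(CCCOc2cc3c(Nc4ccc(F)c(Cl)c4)ncnc3cc2OC)CC1`: 89.3%
compound 2, `CCCCCCCCCCCOC(=O)CCC(=O)N1CCN(CCCOc2cc3c(Nc4ccc(F)c(Cl)c4)ncnc3cc2OC)CC1`: 93.4%

In a functional assay on A549 cells (Homo sapiens) for cytotoxicity, read by MTT assay, with a stated time of 24 h, tested at 10 uM (on this read-out lower numbers stand for a stronger effect and higher numbers for a weaker effect at the one concentration tested), compound 1 gives 89.3% and compound 2 gives 93.4%; the two numbers lie apart by a number 4.1 percentage points higher from compound 1 to compound 2 (within the scatter), so neither stands apart from the other. Compound 3, `CCCCCCCCCCCCCCCCCCOC(=O)CCC(=O)N1CCN(CCCOc2cc3c(Nc4ccc(F)c(Cl)c4)ncnc3cc2OC)CC1`, carries heptyl in place of hydrogen on a saturated chain carbon, ten or more bonds along the chain from an oxygen next to a carbonyl group. Among the compounds with values here, the one measured step that bears on this, a chain lengthening of the same kind, was a number 4.1 percentage points higher from compound 1 to compound 2 (within the scatter), inside the scatter. A further lengthening is therefore expected to give no step beyond the scatter in this assay, amounting to a number 0.6 percentage points higher from compound 2 to compound 3 (within the scatter). For compound 3 the estimate in this assay is 94%, within 85% to 100%.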

Compound 3, a percentage reported as activity, at one concentration (the size of the read-out at that concentration, not a potency): 94.8%
For compound 3 the middle estimate is 0.8 percentage points below the measured one; measured number inside the range.
By their numbers in this assay, from the lowest: compounds 1, 2 and 3 (each within the scatter of the next).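

In this assay, heptyl in place of hydrogen on a saturated chain carbon, ten or more bonds along the chain from an oxygen next to a carbonyl group, gives a number 1.4 percentage points higher from compound 2 to compound 3 (within the scatter). Within the data shown here, the full dodecyl change gives a number 5.5 percentage points higher from compound 1 to compound 3 (within the scatter), so even the largest chain difference stays inside the scatter, which the single earlier step could not show.

Going by these compounds, whether an amine or a carboxylic acid in place of this chain would separate from these numbers in this assay remains open. No measurement shown offers an explanation for the flat read-out.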